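Series notes: benzoyl change from compound 1 to compound 4

This account rests on a few compounds, and the source may have more. Where it says the series, first, only, none or still open, it means among the compounds named here.

Measured so far in an assay on isolated protein for binding affinity to 5-hydroxytryptamine receptor 1B (Homo sapiens); on this read-out higher numbers stand for weaker inhibition and lower numbers for stronger inhibition:
compound 1 `COc1cc2c(cc1N1C[C@@H](C)N(C)[C@@H](C)C1)N(C(=O)c1cccc(Cl)c1Cl)CC2` gives 12.6 nM
compound 2 `COc1cc2c(cc1N1CCN(C)CC1)N(C(=O)c1ccc(-c3cccc(C)n3)c3ccccc13)CC2` gives 2 nM
compound 3 `COc1cc2c(cc1N1C[C@@H](C)N(C)[C@@H](C)C1)N(C(=O)c1ccc(-c3cccc(C)n3)c3ccccc13)CC2` gives 3.16 nM

Compound 1 holds the highest number of the three in this assay; its gaps to compound 3 and to compound 2 both lie beyond the scatter. Going by the values given here, the only step between measured compounds, a 1.6-fold higher number from compound 2 to compound 3 (0.20 log units; within the scatter), concerns the amine ring on the shared core and not the benzoyl part, so it does not bear on the change at hand.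

Compound 4 `COc1cc2c(cc1N1C[C@@H](C)N(C)[C@@H](C)C1)N(C(=O)c1cccc(Cl)c1)CC2` differs from compound 1 by hydrogen in place of chloro on an aromatic carbon. Among the compounds with values here, no measured step informs this change, so the expectation rests on compound 1 alone, with wide bounds. Compound 4 is expected to give about 25 nM in this assay, within 8 nM to 80 nM. The expected step is a 2.0-fold higher number from compound 1 to compound 4 (0.30 log units; within the scatter), which may well fall within the scatter.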

Compound 4, inhibition constant: 20 nM
The estimate for compound 4 lay 1.3-fold (0.10 log units) above the measured number; the measured number falls inside the stated range.
By their numbers in this assay, from the lowest: compounds 2 and 3 (each within the scatter of the next); then compounds 1 and 4 (each within the scatter of the next).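

Hydrogen in place of chloro, taking (2,3-dichlorophenyl)carbonyl to (3-chlorophenyl)carbonyl, gives a 1.6-fold higher number from compound 1 to compound 4 (0.20 log units; within the scatter) in this assay. This chloro, ortho to a chloro group and ortho to a large group, can therefore be lost with no change beyond the scatter, so compound 1 and compound 4 cannot be told apart on this read-out. Nothing at hand offers an explanation for this result.

Going by these compounds, whether a methoxy group or a fluorine at this position would behave alike remains open. So does the effect of also losing the remaining chloro.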